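A Methyl for Fluoro on the Phenol-Bearing Series

The source may hold more compounds than are shown below. What is called first, only, known or untested is meant among the compounds shown, and "the series" means these compounds.

Compound 1 `O=C1Nc2c(ccc(F)c2F)C1(c1ccccc1)c1ccc(O)cc1`: 7.1 nM
Compound 2 `O=C1Nc2c(ccc(F)c2F)C1(c1ccc(O)cc1)c1ccc(F)cc1`: 2.6 nM
Compound 3 `Cc1ccc(C2(c3ccc(O)cc3)C(=O)Nc3c2ccc(F)c3F)cc1`: not yet measured

In a functional assay on MCF7 cells (Homo sapiens) for cytotoxicity, read by WST assay, with a stated time of 72 h (a lower number here means a stronger inhibitor, a higher number a weaker inhibitor), compound 2 holds the lower of the two numbers, at 2.6 nM. Compound 3 departs from it by methyl in place of fluoro on an aromatic carbon. Going by the values given here, only one measured step bears on this place, a 2.7-fold lower number from compound 1 to compound 2 (0.44 log units; beyond the scatter), a modest change that came with fluoro in place of hydrogen. No methyl has been measured here, so the expectation is a small move towards a higher number, perhaps within the scatter. The expected step is a 1.5-fold higher number from compound 2 to compound 3 (0.19 log units; within the scatter). Compound 3 is expected at 4 nM, with an estimated range from 1.5 nM to 11 nM.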

Compound 3, half-maximal inhibitory concentration: 1.7 nM
Estimate against measurement, compound 3: 2.4-fold (0.37 log units) above; low and high end bracket the measured number.
By their numbers in this assay, from the lowest: compounds 3 and 2 (each within the scatter of the next); then compound 1.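

In this assay, methyl and fluoro at this place, para to a large group, cannot be told apart, with a 1.5-fold lower number from compound 2 to compound 3 (0.18 log units; within the scatter). Methyl in place of hydrogen gives a 4.2-fold lower number from compound 1 to compound 3 (0.62 log units; beyond the scatter), so compound 2 and compound 3 both stand beyond the scatter from compound 1, and the earlier gain is no longer tied to fluoro alone. Nothing available explains this result. Going by these compounds, whether an amine, a carboxylic acid or a longer chain at this place would keep the number of compound 2 and compound 3 remains open.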